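A few compounds are considered here, and "the series" means these few. Any claim that something is new, unique, unknown or untested is made for them only; others in the source may bear on it.

Notes on the series in a physicochemical assay for solubility, read by HPLC, in phosphate buffer, with a stated time of 24 h, at pH 6.5 (a higher number here means a more soluble compound, a lower number a less soluble compound), follow. Compound 1 `CCCS(=O)(=O)Nc1ccc(Cl)c(C(=O)Nc2cnc3[nH]nc(OC)c3c2)c1F` gives < 1 ug/mL as a limit and not a number. Compound 2 `CCCS(=O)(=O)Nc1ccc(Cl)c(C(=O)Nc2cnc3[nH]ncc3c2)c1F` gives 15 ug/mL as a measured number. Within the data shown here, compound 3 `CCCS(=O)(=O)Nc1ccc(F)c(C(=O)Nc2cnc3[nH]nc(C)c3c2)c1F` gives 380 ug/mL and holds the highest number so far, beyond the scatter from compound 2.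

Compound 4 `CCCS(=O)(=O)Nc1ccc(F)c(C(=O)Nc2cnc3[nH]nc(Br)c3c2)c1F` differs from compound 3 by bromo in place of methyl on an aromatic carbon with bromo in place of methyl on an aromatic carbon. Among the measured compounds shown here, the one measured step at that place is an at least 15-fold higher number from compound 1 to compound 2 (1.17 log units; beyond the scatter) and it is open-ended, with one end resting on the limit of < 1 ug/mL in this assay, at which 1 of the 3 values shown sits, for compound 1. For the measured compounds named here, that step, hydrogen in place of methoxy, involves neither bromo nor methyl, so it shows only that a swap at this place can move the number far. Going by the values given here, a fall beyond the scatter is expected, with low confidence, as compound 3 at 380 ug/mL stands at the top of the numbers so far. The expected change is a 6.3-fold lower number from compound 3 to compound 4 (0.80 log units; beyond the scatter) as a rough estimate. For compound 4 the estimated value is 60 ug/mL with an expected range from 10 ug/mL to 300 ug/mL for the coming measurement.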

Compound 4, solubility: 1 ug/mL
Compound 4: the middle estimate sits 60-fold (1.78 log units) above what was measured; the whole stated range lies above it.
By their numbers in this assay, from the lowest: compound 4; then compound 2; then compound 3.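

In this assay, among these compounds, bromo in place of methyl on an aromatic carbon gives a 380-fold lower number from compound 3 to compound 4 (2.58 log units; beyond the scatter), and this is the only step at this place with both ends measured. The earlier step at this place, hydrogen in place of methoxy, raised the number and was open-ended, whereas this one lowers it, and the counts of heavy atoms, hydrogen-bond donors and hydrogen-bond acceptors stay the same on both sides. Compound 1 holds the only limit in the series, so any further fall from compound 4 might not be readable as a number: the limit of < 1 ug/mL in this assay, at which 1 of the 4 values shown sits.

The compounds shown leave open where hydrogen, an amine or an ethyl chain at this place would fall relative to methyl and bromo on the core of compound 3. They also leave open whether this step keeps its size with chloro in place of fluoro on the other ring.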